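The compounds below may be only part of what the source reports. "The series", "measured", "known", "first", "only" and "open" are said of these compounds alone.

The measured compounds in an ADME assay on MRC5 cells (Homo sapiens) for cytotoxicity, read by MTT assay, with a stated time of 96 h; on this read-out lower numbers stand for an effect already at smaller amounts and higher numbers for an effect only at larger amounts of compound:

compound 1, `N#C/C(=C\c1c(-c2ccccc2)[nH]c2ccccc12)C(=O)c1cccs1`, gives 20000 nM.
compound 2, `COCCOC(=O)/C(C#N)=C/c1c(-c2ccccc2)[nH]c2ccccc12`, gives only a limit of the assay, > 100000 nM.
compound 3, `CCOC(=O)/C(=C/c1c(-c2ccccc2)[nH]c2ccccc12)C(=O)c1ccccc1`, gives only a limit of the assay, > 100000 nM.

From the compounds shown here alone, compound 2 thus stands at the upper edge of what this assay reports; this is the limit of > 100000 nM in this assay, at which 2 of the 3 values shown sit, so its true number is unknown beyond that edge. Compound 4, `N#C/C(=C\c1c(-c2ccccc2)[nH]c2ccccc12)C(=O)c1ccc(Cl)cc1`, is not yet measured. Its change from compound 2 is 4-chlorophenyl in place of 2-methoxyethoxy on a carbonyl carbon. Going by the values given here, the one measured step that bears on this place is an at least 5.0-fold higher number from compound 1 to compound 2 (0.69 log units; beyond the scatter), which runs the opposite way: replacing a ring on the carbonyl carbon by the 2-methoxyethoxy chain pushed the number from the value of compound 1 to the limit. Compound 3, carrying a ring on its carbonyl carbon but an ester in place of the nitrile, sits at the limit as well. Putting a ring back on the carbonyl carbon of compound 2 is therefore expected to lower the number, and the estimated step is an at least 3.3-fold lower number from compound 2 to compound 4 (0.52 log units; beyond the scatter). Compound 4 is expected to give about 30000 nM, in the range 10000 nM to 100000 nM.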

Compound 4, half-maximal effective concentration: 14000 nM
Estimate against measurement, compound 4: 2.1-fold (0.33 log units) above; low and high end bracket the measured number.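

In this assay, 4-chlorophenyl in place of 2-methoxyethoxy on the carbonyl carbon gives an at least 7.1-fold lower number from compound 2 to compound 4 (0.85 log units; beyond the scatter), so the step first seen with the thiophen-2-yl ring now appears with a second, different ring. The two rings cannot be told apart here, as 4-chlorophenyl in place of thiophen-2-yl gives a 1.4-fold lower number from compound 1 to compound 4 (0.15 log units; within the scatter). Compound 2 is only a limit, so the full size of its step to compound 4 cannot be read: the limit of > 100000 nM in this assay, at which 2 of the 4 values shown sit.

Going by these compounds alone, with only two rings and one chain at this place, it remains open whether an aromatic ring is needed or any group other than 2-methoxyethoxy would do. A saturated cyclohexyl ring, a short methyl group or an amine on the same carbonyl carbon could bring the number close to either side.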